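This account rests on a few compounds, and the source may have more. Where it says the series, first, only, none or still open, it means among the compounds named here.

Compound 1 `COc1ccc([C@H]2CC(=O)N(c3ccccc3)C2)cc1OC1CCCC1` sits at a limit of a functional assay on HEK293 cells (Homo sapiens) for cytotoxicity (a lower number here means that less compound is tolerated, a higher number that more compound is tolerated), rather than at a number, giving > 10000 nM. Compound 2 `COc1ccc([C@H]2CC(=O)N(c3ccc(C(F)(F)F)cc3)C2)cc1OC1CCCC1` likewise reaches only a limit in this assay, giving > 10000 nM. Compound 3 `COc1ccc([C@H]2CC(=O)N(c3ccc([S+](C)[O-])cc3)C2)cc1OC1CCCC1` gives a number in this assay, 7510 nM. Two of the three values therefore sit at the same limit (the limit of > 10000 nM in this assay, at which 2 of the 3 values shown sit). Compound 4 `COc1ccc([C@H]2CC(=O)N(c3cccc(NS(=O)(=O)c4ccccc4F)c3)C2)cc1OC1CCCC1` is not yet measured; it differs from compound 1 by ((2-fluorophenyl)sulfonyl)amino in place of hydrogen on an aromatic carbon. The measured steps at this same position are a step that the two limits leave unreadable from compound 1 to compound 2, an at least 1.3-fold lower number from compound 1 to compound 3 (0.12 log units; that floor lies within the scatter) and an at least 1.3-fold lower number from compound 2 to compound 3 (0.12 log units; that floor lies within the scatter), none of them readable beyond the scatter. For the step to compound 4 no move beyond the scatter is expected, an at least 1.1-fold lower number from compound 1 to compound 4 (0.04 log units; that floor lies within the scatter). Compound 4 is estimated at 9000 nM, within 3000 nM to 30000 nM.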

Compound 4, half-maximal cytotoxic concentration: > 10000 nM
Compound 4 ended at the assay's limit; the forecaster's own chance of this, stated with the estimate: 55%; middle value at least 1.1-fold (0.04 log units) from the limit.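

In this assay compound 4 gives > 10000 nM, a limit, and compound 1 also stands at a limit, so no step between them can be read: the limit of > 10000 nM in this assay, at which 3 of the 4 values shown sit.

The compounds shown leave open whether ((2-fluorophenyl)sulfonyl)amino in place of hydrogen changes the number at all.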